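The compounds below may be only part of what the source reports. "The series", "measured", "known", "first", "only" and "open" are said of these compounds alone.

Measured so far in an assay on HEK293 cells for agonist activity at Toll-like receptor 8 (Homo sapiens), read by a luciferase reporter, with a stated time of 6 h; a higher number here means that more compound is needed for the effect, a lower number that less compound is needed:
compound 1 `CCCCNc1nc(N)nc2c1CN(S(C)(=O)=O)CC2` gives 9.9 uM
compound 2 `CCCCNc1nc(N)nc2c1CN(Cc1ccccc1Cl)CC2` gives 0.05 uM

Going by the values given here, of these two, compound 2 stands with the lower number, and the single step known, a 200-fold lower number from compound 1 to compound 2 (2.30 log units; beyond the scatter), is large and well beyond the scatter. Compound 3 `CCCCNc1nc(N)nc2c1CN(Cc1cc(F)cc(F)c1)CC2` differs from compound 2 in one place: 3,5-difluorophenyl in place of 2-chlorophenyl on a saturated chain carbon bound to an amine nitrogen in a ring. Among the compounds with values here, no measured step bears directly on this change: the one step recorded concerns the exchange of methylsulfonyl for 2-chlorobenzyl on the amine nitrogen in the ring, and both compound 2 and compound 3 keep a benzyl-type group at that position. Within the data shown here, what is known is only that a benzyl-type group there gives a far lower number than methylsulfonyl. Compound 3 is therefore expected to stay near compound 2, with a small step of a 2.0-fold higher number from compound 2 to compound 3 (0.30 log units; within the scatter) that may or may not exceed the scatter. The estimate for compound 3 in this assay is 0.1 uM, within a range of 0.02 uM to 0.5 uM.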

Compound 3, minimum effective concentration: 0.23 uM
Compound 3: middle estimate off by 2.3-fold (0.36 log units), on the low side, and the stated range covers the measured number.
By their numbers in this assay, from the lowest: compound 2; then compound 3; then compound 1.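

In this assay, the phenyl group on the saturated chain carbon bound to an amine nitrogen in a ring proves sensitive to its substituents: 3,5-difluorophenyl in place of 2-chlorophenyl gives a 4.6-fold higher number from compound 2 to compound 3 (0.66 log units; beyond the scatter), a modest step beyond the scatter. The earlier step, a 200-fold lower number from compound 1 to compound 2 (2.30 log units; beyond the scatter), set a benzyl-type group against methylsulfonyl, whereas this one shows that the number also shifts among benzyl-type groups, though by less. Nothing available explains this shift.

The two compounds leave open whether the shift follows the loss of the chlorine, the arrival of the two fluorines, or their placing, since all of these change together. As far as these compounds go, how plain phenyl, 2-fluorophenyl or 3-chlorophenyl would read at this position also remains open.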